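The compounds below may be only part of what the source reports. "The series", "measured", "known", "first", "only" and "open" are said of these compounds alone.

Compound 3, with structure `CCCCC(=O)OCc1ccc2oc(=O)c(C(=O)Oc3cccc(Br)c3)cc2c1`, is one of three coumarin-type esters examined in a functional assay on HT-1080 cells (Homo sapiens), read by transwell migration, with a stated time of 24 h, tested at 1 uM; a higher number here means a weaker effect of the compound at the concentration tested, a lower number a stronger effect. There compound 3 gives 63.3%, the second highest of the three numbers; compound 1 `CC(=O)OCc1ccc2oc(=O)c(C(=O)Nc3cccc(Cl)c3)cc2c1` gives 66.9%, which lies within the scatter of compound 3, while compound 2 `CCC(=O)OCc1ccc2oc(=O)c(C(=O)Oc3cccc(Br)c3)cc2c1` gives 40.2%, a gap beyond the scatter. Among the measured compounds shown here, the only measured step, a number 23.1 percentage points higher from compound 2 to compound 3 (beyond the scatter), concerns chain length. For the measured compounds named here, compound 4 `CC(C)(C)C(=O)OCc1ccc2oc(=O)c(C(=O)Oc3cccc(Br)c3)cc2c1` differs from compound 3 by tert-butyl in place of butyl on a carbonyl carbon, a rearrangement of the same atoms rather than a change in their count; no measured step addresses such a rearrangement. The step of a number 3.3 percentage points lower from compound 3 to compound 4 (within the scatter) is therefore expected to stay within the scatter. Compound 4 is estimated to give 60%, between 40% and 80%.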

Compound 4, a percentage reported as activity, at one concentration (the size of the read-out at that concentration, not a potency): 48.2%
Estimate against measurement, compound 4: 11.8 percentage points above; the range from low to high includes it.
By their numbers in this assay, from the lowest: compounds 2 and 4 (each within the scatter of the next); then compounds 3 and 1 (each within the scatter of the next).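

In this assay the arrangement of the carbons at this carbonyl carbon counts, not only their number: butyl to tert-butyl gives a number 15.1 percentage points lower from compound 3 to compound 4 (beyond the scatter) with no atom gained or lost. The other comparison gives a number 8 percentage points higher from compound 2 to compound 4 (within the scatter) for the change from ethyl to tert-butyl, so a chain of the same count as butyl need not keep the higher number when branched. No measurement shown offers a reason for either step. Going by these compounds, whether a cyclopropyl or phenyl group here would stay within the scatter of compound 2 remains open, as does the effect of a longer chain.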